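From compound 1 to compound 3: one aryl group exchanged

The compounds below may be only part of what the source reports. "The series", "measured", "known", "first", "only" and "open" are said of these compounds alone.

In an ADME assay on microsomes from liver (Homo sapiens) for metabolic stability (a lower number here means that the compound disappears faster, a higher number that the compound lasts longer), compound 1 `COc1cc(OCc2cccc(-c3ccc(OC)nc3)c2)c2cc(-c3cn4nc(OC)sc4n3)oc2c1` gives 0.733 h and holds the lower of the two numbers, with compound 2 `COc1cc(OCc2csc(-c3ccc(C(C)(C)O)cc3)n2)c2cc(-c3cn4nc(OC)sc4n3)oc2c1` at 1.83 h and the gap beyond the scatter. These two differ in more than one place, so neither sets a size for the change at hand. Compound 3 `COc1cc(OCc2cccc(-c3ccc(C#N)cc3)c2)c2cc(-c3cn4nc(OC)sc4n3)oc2c1` carries 4-cyanophenyl in place of 6-methoxypyridin-3-yl on an aromatic carbon with the rest of compound 1 unchanged. Within the data shown here, with no measured step available, a small upward move in this assay is expected, and the estimated step of a 1.4-fold higher number from compound 1 to compound 3 (0.13 log units; within the scatter) stays within the scatter. For compound 3 the expected half-life is 1 h with a range from 0.5 h to 2.1 h as estimated.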

Compound 3, half-life: > 2 h
Compound 3 ended at the assay's limit; the forecaster's own chance of this, stated with the estimate: 5%; at least 2.0-fold (0.30 log units) between middle value and limit.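

In this assay, among these compounds, 4-cyanophenyl in place of 6-methoxypyridin-3-yl, on an aromatic carbon meta to a large group, gives the first one-place step: an at least 2.7-fold higher number from compound 1 to compound 3 (0.43 log units; beyond the scatter). Compound 3 gives > 2 h, which is a limit of the assay and not a number. The aryl group at this position therefore moves the half-life beyond the scatter, but the step sets only a lower bound on its size: the limit of > 2 h in this assay, at which 1 of the 3 values shown sits.

As far as these compounds go, what a plain phenyl or a 4-methoxyphenyl group gives here remains open. So does whether the higher number follows the nitrile, the loss of the methoxy group or the loss of the ring nitrogen.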